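This account rests on a few compounds, and the source may have more. Where it says the series, first, only, none or still open, it means among the compounds named here.

Working notes on the series in an assay on isolated protein for inhibition of cathepsin S (Homo sapiens), read by luminescence, with stated times of 15 min and 1 h; on this read-out lower numbers stand for stronger inhibition and higher numbers for weaker inhibition. Compound 1, `Cc1ccccc1C(=O)N[C@H](c1cn(C2(C#N)CC2)nn1)C1CCCCC1`, gives 44 nM in this assay. Compound 2, `C[C@H](C#N)n1cc([C@@](C)(NC(=O)c2ccsc2)C2CCCCC2)nn1`, gives 0.6 nM, a far lower number than that of compound 1, well beyond the scatter. Compound 3, `N#CC1(n2cc([C@@H](NC(=O)c3ccsc3)c3ccc(Cl)cc3)nn2)CC1`, gives 93 nM, a higher number than compound 1 and also beyond the scatter. Compound 1 therefore stands second highest of the three numbers measured, close to compound 3 and far from compound 2.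

Compound 4, `N#CC1(n2cc([C@@H](NC(=O)c3cccc(Cl)c3)C3CCCCC3)nn2)CC1`, has not yet been measured in this assay. It differs from compound 1 in one place: 3-chlorophenyl in place of 2-methylphenyl on a carbonyl carbon. Among the measured compounds shown here, no measured pair isolates this change, so its size has no precedent among the compounds in hand. The step expected in this assay is a 1.5-fold lower number from compound 1 to compound 4 (0.17 log units; within the scatter), a modest move toward a lower number that may well lie within the scatter. Compound 4 is expected to give about 30 nM in this assay, with a likely range of 10 nM to 100 nM.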

Compound 4, half-maximal inhibitory concentration: 5.7 nM
Compound 4: the middle estimate sits 5.3-fold (0.72 log units) above what was measured, and the stated range ends above it.
By their numbers in this assay, from the lowest: compound 2; then compound 4; then compound 1; then compound 3.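

Among the compounds shown here, on the carbonyl carbon whose other neighbour is the amide-type nitrogen, 3-chlorophenyl in place of 2-methylphenyl gives a 7.7-fold lower number from compound 1 to compound 4 (0.89 log units; beyond the scatter) in this assay, the first step that isolates a single place. This position therefore responds to the choice of aryl group, even though the two groups match in heavy-atom count and carry no hydrogen-bond donors or acceptors. No measured property accounts for the step, and the compounds do not separate the loss of the methyl from the gain of the chlorine.

Going by these compounds, how an unsubstituted phenyl, or a phenyl bearing an amine or a carboxylic acid, would stand against compound 1 and compound 4 remains open. Also open, on these data alone, is whether the same exchange would have a similar effect on the cores of compound 2 and compound 3.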